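Lengthening a Chain on Two Related Cores

This account rests on a few compounds, and the source may have more. Where it says the series, first, only, none or still open, it means among the compounds named here.

Compound 1 `CCCCCCCC(CCO)n1cnc2c(N)nc(Cl)nc21` and compound 3 `CCCCCCCCC(CCO)n1cnc2c(N)nc(Cl)nc21` share a core and differ by methyl in place of hydrogen on a saturated chain carbon, eight bonds along the chain from an aromatic nitrogen. In a functional assay on SW480 cells (Homo sapiens) for antiproliferative activity, read by MTT assay, with a stated time of 48 h (on this read-out higher numbers stand for weaker inhibition and lower numbers for stronger inhibition), compound 1 reaches only the limit > 50000 nM, which is one of the assay's limits the limit of > 50000 nM in this assay, at which 1 of the 3 values shown sits, and not a number. Compound 3 gives 13100 nM in this assay, so the step of an at least 3.8-fold lower number from compound 1 to compound 3 (0.58 log units; beyond the scatter). Compound 2 `CCCCCCCCC(CCO)n1cnc2c(Cl)nc(F)nc21` carries a different core; how its core differs from that of compound 1 is not broken down here. In this assay compound 2 gives 15000 nM, a value that sits within the scatter of compound 3. Compound 4 `CCCCCCCCCC(CCO)n1cnc2c(Cl)nc(F)nc21` is not yet measured and differs from compound 2 by methyl in place of hydrogen on a saturated chain carbon, nine bonds along the chain from an aromatic nitrogen. Among the compounds with values here, this is the same kind of change as the one from compound 1 to compound 3, though here the added methyl sits nine bonds along the chain from an aromatic nitrogen rather than eight. Drawing on that earlier step, the change from compound 2 to compound 4 is expected to give a 2.1-fold lower number from compound 2 to compound 4 (0.33 log units; beyond the scatter). Compound 4 is therefore estimated at 7000 nM in this assay, likely between 2500 nM and 20000 nM.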

Compound 4, half-maximal inhibitory concentration: 12500 nM
The estimate for compound 4 lay 1.8-fold (0.25 log units) below the measured number, within the range that was stated.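

In this assay the added methyl on the core of compound 2 gives a 1.2-fold lower number from compound 2 to compound 4 (0.08 log units; within the scatter), so on this core lengthening the chain shows no effect beyond the scatter. The same change therefore does not carry over with the same size from one core to the other: the same change on two cores in this assay, an at least 3.8-fold lower number (0.58 log units; beyond the scatter) from compound 1 to compound 3 and a 1.2-fold lower number (0.08 log units; within the scatter) from compound 2 to compound 4, at least 3.1-fold (0.50 log units) apart, beyond the scatter of two such steps. Within the data shown here, this does not show which feature of the cores sets the two steps apart, and with only one pair on each core it gives no general rule, while the earlier step starts from compound 1, whose value is a limit and not a number: the limit of > 50000 nM in this assay, at which 1 of the 4 values shown sits.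

The compounds shown leave open whether a still longer chain would bring a step beyond the scatter on either core, and what an amine or a carboxylic acid on the chain would do. They also leave open how large the step on the core of compound 1 really is, since only its lower bound can be read.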